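Swapping ethyl for tert-butyl on the ester of compound 2

A few compounds are considered here, and "the series" means these few. Any claim that something is new, unique, unknown or untested is made for them only; others in the source may bear on it.

Of the compounds shown here, two have been measured in a functional assay on DLD-1 cells (Homo sapiens) for cytotoxicity, with a stated time of 48 h; on this read-out lower numbers stand for stronger inhibition and higher numbers for weaker inhibition. Compound 1, `C[S+]([O-])/C=C/c1cc(=O)c2cc(F)ccc2o1`, gives 7000 nM. Compound 2, `CCC(=O)Oc1ccc2oc(/C=C/[S+](C)[O-])cc(=O)c2c1`, gives 9000 nM. Among these two numbers compound 2 stands highest, but its only neighbour is close: a 1.3-fold higher number from compound 1 to compound 2 (0.11 log units; within the scatter), a change that exchanges propanoyloxy for fluoro on an aromatic carbon and leaves the read-out essentially where it was.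

Compound 3, `C[S+]([O-])/C=C/c1cc(=O)c2cc(OC(=O)C(C)(C)C)ccc2o1`, has not been measured. It differs from compound 2 at the ester end: tert-butyl in place of ethyl on a carbonyl carbon. For the measured compounds named here, no measured step touches this carbonyl carbon, so nothing here speaks directly to the exchange of ethyl for tert-butyl. Going by the values given here, the one step that exists, from compound 1 to compound 2, altered the group on the aromatic carbon and stayed within the scatter, which gives no hint that this part of the molecule is sensitive to small changes. The expectation is therefore no step beyond the scatter, no change at the digits printed from compound 2 to compound 3 (within the scatter). Compound 3 is estimated at 9000 nM, with a range from 4000 nM to 20000 nM.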

Compound 3, half-maximal inhibitory concentration: 8000 nM
Compound 3: middle estimate off by 1.1-fold (0.05 log units), on the high side, and the stated range covers the measured number.
By their numbers in this assay, from the lowest: compounds 1, 3 and 2 (each within the scatter of the next).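

The ester's carbonyl carbon is now shown to tolerate a change in this assay: going from ethyl, with 2 heavy atoms, to tert-butyl, with 4, gives a 1.1-fold lower number from compound 2 to compound 3 (0.05 log units; within the scatter) and so does not separate the two esters. The comparison with the fluoro compound gives a 1.1-fold higher number from compound 1 to compound 3 (0.06 log units; within the scatter) and extends the earlier finding from propanoyloxy to ((tert-butyl)carbonyl)oxy: on this aromatic carbon, fluoro and both esters cannot be told apart on this read-out. Nothing available explains why these exchanges leave the number so flat.

On these data alone, all three compounds sit in the same narrow band, so it remains open whether any group at this place can move the number beyond the scatter, and an amine or a carboxylic acid on the aromatic carbon, or a longer chain such as octyl on the carbonyl carbon, would put that to the test. As far as these compounds go, the sulfur-bearing side chain is identical throughout, so how much that part of the molecule contributes to the cytotoxicity also remains unknown.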